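Series notes: replacing the aryl group on the nitrogen

This account rests on a few compounds, and the source may have more. Where it says the series, first, only, none or still open, it means among the compounds named here.

Measured in a functional assay on A549 cells (Homo sapiens) for antiproliferative activity, read by MTT assay, with a stated time of 72 h; on this read-out lower numbers stand for stronger inhibition and higher numbers for weaker inhibition:
- compound 1 `CN1CCN(Cc2ccc(NC(=O)Nc3ccc4ncnc(Nc5ccc(F)c(F)c5)c4c3)cc2)CC1`: > 10000 nM (a limit, not a number)
- compound 2 `COc1ccc(Nc2ncnc3ccc(NC(=O)Nc4ccc(CN5CCN(C)CC5)cc4)cc23)cc1Cl`: 3570 nM
- compound 3 `C[C@@H](Nc1ncnc2ccc(NC(=O)Nc3ccc(CN4CCN(C)CC4)cc3)cc12)c1ccccc1`: not yet measured

Compound 1 gives only a limit: the limit of > 10000 nM in this assay, at which 1 of the 2 values shown sits. Going by the values given here, compound 2, at 3570 nM, therefore carries the only actual number so far.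

The change now in view is 1-phenylethyl in place of 3-chloro-4-methoxyphenyl on a nitrogen on an aromatic ring. In words, 1-phenylethyl takes the place of 3-chloro-4-methoxyphenyl on a nitrogen on an aromatic ring.

Among the compounds with values here, the one measured step, an at least 2.8-fold lower number from compound 1 to compound 2 (0.44 log units; beyond the scatter), sits at this same place, so it is the only guide. It shows that this assay can respond to the group on this nitrogen, but it covers a swap between two substituted phenyl groups. Within the data shown here, no measured step covers a 1-phenylethyl group.

A modest move toward a higher number is therefore expected, on the scale of the step to compound 2, with no change beyond the scatter also possible. The expected step is a 1.5-fold higher number from compound 2 to compound 3 (0.19 log units; within the scatter). The estimate for compound 3 is 5500 nM, with an expected range of 1800 nM to 12000 nM.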

Compound 3, half-maximal inhibitory concentration: > 10000 nM
Compound 3: only a limit was reported (the forecaster's own chance of this, stated with the estimate: 30%); middle value at least 1.8-fold (0.25 log units) from the limit.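

In this assay compound 3 gives only a limit, > 10000 nM. The step is still readable: 1-phenylethyl in place of 3-chloro-4-methoxyphenyl on this nitrogen gives an at least 2.8-fold higher number from compound 2 to compound 3 (0.44 log units; beyond the scatter), so the read-out responds here to a change from a substituted phenyl group to 1-phenylethyl, and not only to a swap between two substituted phenyl groups. The step from compound 1 to compound 3 cannot be read, because both values are limits, and 3-chloro-4-methoxyphenyl remains the only group on this nitrogen with an actual number: the limit of > 10000 nM in this assay, at which 2 of the 3 values shown sit.

The compounds shown do not separate the contribution of the 1-phenylethyl methyl group or its defined stereocentre from that of losing the chlorine and methoxy substituents, and they give no actual number for any group other than 3-chloro-4-methoxyphenyl. As far as these compounds go, a plain benzyl group, the opposite enantiomer of 1-phenylethyl, and a phenyl ring bearing an amine or a longer alkoxy chain would each address a part of this that remains open.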